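The compounds below may be only part of what the source reports. "The series", "measured", "known", "first", "only" and "open" are said of these compounds alone.

Among the measured compounds shown here, in an ADME assay on L6 cells (Rattus norvegicus) for cytotoxicity (a higher number here means a weaker inhibitor, a lower number a stronger inhibitor), compound 1 (`COc1cc2c(cc1C(C)OCc1ccccc1)C=CC(C)(C)O2`) gives 43900 nM and compound 2 (`CCCCNC(C)c1cc2c(cc1OC)OC(C)(C)C=C2`) gives 52500 nM, so compound 2 stands within the scatter of the only other measured value. Compound 3 (`COc1cc2c(cc1C(C)N1CCCC1)C=CC(C)(C)O2`) differs from compound 2 as follows: pyrrolidin-1-yl in place of butylamino on a saturated chain carbon bound to an aromatic carbon and a saturated chain carbon. Here pyrrolidin-1-yl takes the place of butylamino on the same saturated chain carbon. For the measured compounds named here, the only measured step at this carbon is a 1.2-fold higher number from compound 1 to compound 2 (0.08 log units; within the scatter), so no step beyond the scatter is expected in this assay. The expected change is a 1.1-fold lower number from compound 2 to compound 3 (0.04 log units; within the scatter). Compound 3 is estimated at 48000 nM, with an expected range of 25000 nM to 90000 nM.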

Compound 3, half-maximal inhibitory concentration: 177000 nM
Estimate against measurement, compound 3: 3.7-fold (0.57 log units) below; measured number above the stated range.
By their numbers in this assay, from the lowest: compounds 1 and 2 (each within the scatter of the next); then compound 3.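

In this assay, the saturated chain carbon bound to an aromatic carbon and a saturated chain carbon proves sensitive to its substituent: the step with pyrrolidin-1-yl replacing butylamino is a 3.4-fold higher number from compound 2 to compound 3 (0.53 log units; beyond the scatter), and the step with it replacing benzyloxy is a 4.0-fold higher number from compound 1 to compound 3 (0.61 log units; beyond the scatter). The earlier pair had shown no change beyond the scatter, so this is the first sign that the group here matters. No measurement shown accounts for this step.

This change adds a ring and removes a hydrogen-bond donor together, so the compounds shown cannot separate the two. Diethylamino, an open-chain amine without that donor, would address this, and piperidin-1-yl would test ring size.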